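A few compounds are considered here, and "the series" means these few. Any claim that something is new, unique, unknown or untested is made for them only; others in the source may bear on it.

Measured compounds:
- compound 1, `CC/C=C/[C@H](CC)C[C@@]1(C)C[C@@H](CC)[C@@H](CC(=O)OC)OO1`: 10.4 ug/mL
- compound 3, `CC/C=C/[C@H](CC)C[C@]1(CC)C=C(CC)/C(=C/C(=O)OC)O1`: 9.6 ug/mL
- compound 2, `CC/C=C/[C@H](CC)C/C(=C/[C@@]1(CC)C[C@H](CC)[C@H](CC(=O)O)OO1)CC`: "not determined" (no result reported)

In a functional assay on MDA-MB-435 cells (Homo sapiens) for cytotoxicity (a higher number here means a weaker inhibitor, a lower number a stronger inhibitor), compound 1 gives 10.4 ug/mL and compound 3 gives 9.6 ug/mL. Compound 3 holds the lowest of the two numbers, but its gap to compound 1 lies within the scatter, so the two values are read as equivalent. For compound 2 no number exists in this assay, so it adds nothing to the comparison.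

The step under consideration leads from compound 3 to compound 4, `CC/C=C/[C@H](CC)C[C@]1(C)C=C(CC)/C(=C/C(=O)OC)O1`. The change is hydrogen in place of methyl on a saturated chain carbon bound to a saturated ring carbon. Within the data shown here, no step between two measured compounds isolates that change, so there is no measured precedent for it. Compound 1, which carries the methyl on the corresponding saturated ring carbon in a different core, sits at 10.4 ug/mL, in line with compound 3, which is the only hint available that the ethyl-to-methyl exchange leaves the number where it is.

The expectation for compound 4 in this assay is a step of a 1.0-fold higher number from compound 3 to compound 4 (0.02 log units; within the scatter), that is, nothing beyond the scatter in either direction. The estimate for compound 4 is 10 ug/mL, with a range from 5 ug/mL to 20 ug/mL.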

Compound 4, half-maximal inhibitory concentration: > 25 ug/mL
Compound 4: no number, only a limit; the forecaster's own chance of this, stated with the estimate: 10%; middle value at least 2.5-fold (0.39 log units) away from the limit.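

Hydrogen in place of methyl on a saturated chain carbon bound to a saturated ring carbon, which amounts to ethyl to methyl, now has a first reading between two measured compounds, and it gives an at least 2.6-fold higher number from compound 3 to compound 4 (0.41 log units; beyond the scatter). Among these compounds, this shows that, on the shared core, the number in this assay responds to this exchange at this position, which no earlier pair could show. In this assay compound 4 gives > 25 ug/mL, which is a limit of the assay and not a number, so the step marks only a minimum for this change, and its full size stays unread: the limit of > 25 ug/mL in this assay, at which 1 of the 4 values shown sits.

As far as these compounds go, whether a longer chain such as propyl, or an amine on the same chain, would keep the number of the ethyl compound or move it further stays open. Also open is whether the exchange counts in the same way on the core of compound 1, which carries the methyl group and gives 10.4 ug/mL, as the compounds shown hold no pair on that core that reads it.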